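A few compounds are considered here, and "the series" means these few. Any claim that something is new, unique, unknown or untested is made for them only; others in the source may bear on it.

Measured compounds:
- compound 1 `CC1CCCc2c1[nH]c(=O)c(C#N)c2-c1cccn1C` — > 100000 nM (a limit)
- compound 2 `Cn1cccc1-c1cc(-c2cccs2)[nH]c(=O)c1C#N` — > 100000 nM (a limit)

Both numbers shown are limits of the assay, not measured values. In a functional assay on BT-549 cells (Homo sapiens) for inhibition, read by sulforhodamine B assay, with a stated time of 48 h (a higher number here means a weaker inhibitor of growth, a lower number a stronger inhibitor of growth), compound 1 gives > 100000 nM, which is a limit. In this assay compound 2 gives > 100000 nM, again a limit. Compound 2 therefore stands at the upper edge of what this assay reports, together with the only other compound shown: the limit of > 100000 nM in this assay, at which 2 of the 2 values shown sit.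

Compound 3 `Cn1cccc1-c1cc(-c2ccccc2)[nH]c(=O)c1C#N` has not been measured yet. It differs from compound 2 in one place: phenyl in place of thiophen-2-yl on an aromatic carbon. Phenyl in place of thiophen-2-yl on an aromatic carbon is the whole of the change.

Within the data shown here, no step between measured compounds is available, so the size of this change in this assay has no direct precedent. Given that compound 2 sits at a limit, the expectation for this assay is no step beyond the scatter, with a limit again the most likely outcome. Compound 3 is expected at 150000 nM, within a range from 50000 nM to 500000 nM. The step this estimate implies, a step that the limit leaves unreadable from compound 2 to compound 3, is expected to be none beyond the scatter.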

Compound 3, concentration for 50% growth inhibition: 85100 nM
Beside the measured number, compound 3's estimate is 1.8-fold (0.25 log units) above it; low and high end bracket the measured number.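

In this assay, phenyl in place of thiophen-2-yl on an aromatic carbon next to the ring nitrogen gives an at least 1.1-fold lower number from compound 2 to compound 3 (0.07 log units; that floor lies within the scatter). Compound 3 gives 85100 nM, a measured number rather than a limit, so with phenyl at this position the growth read-out falls inside the range that this assay can report, though only weak inhibition is seen. The true size of the step cannot be read because compound 2 sits at a limit, so the swap cannot be ranked beyond that floor, and compound 1 differs from compound 3 in more than one place: the limit of > 100000 nM in this assay, at which 2 of the 3 values shown sit.

Still open, on these data alone, is whether a phenyl carrying an amine or a carboxylic acid, or a longer alkyl chain in place of the aromatic ring at this position, would move the number in this assay clearly beyond the scatter. No pair shown varies the 1-methyl-1H-pyrrol-2-yl group alone, so its contribution to the value of compound 3 remains unknown.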